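Working notes on compounds 1 to 4

The compounds below may be only part of what the source reports. "The series", "measured", "known", "first", "only" and "open" are said of these compounds alone.

For the measured compounds named here, all numbers so far come from a functional assay on the whole organism (artery, strain albino) with Rattus norvegicus as the target, with a stated time of 120 min, at a dose of 10 mg/kg by the oral route; a lower number here means less inhibition, a higher number more inhibition at the dose given (going by the name of the read-out).
compound 1, `COc1ccc(C2N=C(SCc3cccc(Cl)c3)NC(C)=C2C(=O)Nc2ccc(F)cc2)cc1OC`: 10.8%
compound 2, `COc1ccc(C2N=C(SCc3ccc(Cl)cc3)NC(C)=C2C(=O)Nc2ccc(F)cc2)cc1OC`: 15.5%
compound 3, `COc1ccc(C2N=C(SCc3cccc(Cl)c3)NC(C)=C2C(=O)Nc2ccc(Br)cc2)cc1`: 21.1%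

Compounds 1 and 2 share one core, compounds 3 and 4 another; the difference between the two cores is not broken down here. Compound 4, `COc1ccc(C2N=C(SCc3ccc(Cl)cc3)NC(C)=C2C(=O)Nc2ccc(Br)cc2)cc1`, has not yet been measured in this assay.

From compound 1 to compound 2 the change is 4-chlorophenyl in place of 3-chlorophenyl on a saturated chain carbon bound to a sulfur, and it gave a number 4.7 percentage points higher from compound 1 to compound 2 (within the scatter). Compound 3 holds the highest of the three measured numbers, but only its gap to compound 1 lies beyond the scatter; compound 3 and compound 2 lie within the scatter of each other.

From compound 3 to compound 4 the change is 4-chlorophenyl in place of 3-chlorophenyl on a saturated chain carbon bound to a sulfur, on the core of compound 3. The place is the same in both pairs, so this is the same change seen once before. For compound 4 a step of about the earlier size is expected, a number 3.9 percentage points higher from compound 3 to compound 4 (within the scatter), because a number 4.7 percentage points higher from compound 1 to compound 2 (within the scatter) stayed within the scatter. Compound 4 is therefore estimated at 25%, somewhere between 13% and 38%.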

Compound 4, a percentage reported as inhibition, in the whole organism at one dose (the size of the read-out at that dose, not a potency): 16.5%
Compound 4: the middle estimate sits 8.5 percentage points above what was measured; measured number inside the range.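

In this assay, 4-chlorophenyl in place of 3-chlorophenyl on a saturated chain carbon bound to a sulfur gives a number 4.6 percentage points lower from compound 3 to compound 4 (within the scatter). Set beside the earlier step, the change shows no difference between the two cores that can be told from the usual scatter: the same change on two cores in this assay, a number 4.7 percentage points higher (within the scatter) from compound 1 to compound 2 and a number 4.6 percentage points lower (within the scatter) from compound 3 to compound 4, 9.3 percentage points apart, within the scatter of two such steps. This does not show that the change carries over unaltered from one core to the other, nor that the two steps truly point in opposite directions; two pairs with steps this small neither establish nor exclude a modest influence of the core on the inhibition seen at this single oral dose.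

The compounds shown leave open whether a benzyl group carrying an amine or a carboxylic acid in place of the chlorine would give a step beyond the scatter. Also open, on these data alone, is what a longer chain on the sulfur, in place of the chlorobenzyl group, would do on either core.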